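A pyridin-2-yl swap at the assay limit

The source may hold more compounds than are shown below. What is called first, only, known or untested is meant among the compounds shown, and "the series" means these compounds.

Compound 1 `COc1ccc(C(=O)/C=C/c2ccc(F)cc2)c2c1C=CC(C)(C)O2`: > 10000 nM, a limit
Compound 2 `COc1ccc(/C=C/C(=O)c2ccc(OC)c3c2OC(C)(C)C=C3)cn1`: > 10000 nM, a limit

In a functional assay on SW-620 cells (Homo sapiens) for antiproliferative activity, read by MTT assay, with a stated time of 24 h (a higher number here means a weaker inhibitor, a lower number a stronger inhibitor), compound 2 stands only at a limit, > 10000 nM. Compound 1 also stands only at a limit, > 10000 nM. All that is known so far is the limit of > 10000 nM in this assay, at which 2 of the 2 values shown sit.

Compound 3 `COc1ccc(C(=O)/C=C/c2ccccn2)c2c1C=CC(C)(C)O2` departs from compound 2 in one place: pyridin-2-yl in place of 6-methoxypyridin-3-yl on a double-bonded chain carbon bound to a double-bonded chain carbon. It carries pyridin-2-yl in place of 6-methoxypyridin-3-yl, on a double-bonded chain carbon bound to a double-bonded chain carbon. Within the data shown here, the only measured step at this place is a step that the two limits leave unreadable from compound 1 to compound 2. Among the measured compounds shown here, with no readable size behind it, no step of known size or direction is expected in this assay, and a result near the same limit seems likely. The estimated step is a step that the limit leaves unreadable from compound 2 to compound 3. Compound 3 is estimated at 12000 nM, with an expected range from 5000 nM to 30000 nM.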

Compound 3, half-maximal inhibitory concentration: 5000 nM
Compound 3: middle estimate off by 2.4-fold (0.38 log units), on the high side; low and high end bracket the measured number.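

At this place on the chain, a readable number appears only with pyridin-2-yl: compound 3 is the one compound of the three that is not at a limit: the limit of > 10000 nM in this assay, at which 2 of the 3 values shown sit.

The step between the other two compounds cannot be read, but in this assay the change to pyridin-2-yl gives an at least 2.0-fold lower number from compound 2 to compound 3 (0.30 log units; that floor lies within the scatter) and an at least 2.0-fold lower number from compound 1 to compound 3 (0.30 log units; that floor lies within the scatter). Both are only floors, and both lie within the scatter, so the position can be said to allow a measurable value, but no real gain is established.

Going by these compounds, the true size of either step stays open, as does whether the change in compound 3 depends on the place of the ring nitrogen or on the loss of the methoxy group. Pyridin-3-yl, pyridin-4-yl or unsubstituted phenyl on the same chain carbon would help to separate these two changes.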